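Swapping Methoxy for Chloro on a Shared Core

This account rests on a few compounds, and the source may have more. Where it says the series, first, only, none or still open, it means among the compounds named here.

Compound 1, `NS(=O)(=O)c1ccc(NC2=NC(=O)/C(=C/c3ccc(Cl)cc3)S2)cc1`, gives 667 nM in a functional assay on Caco-2 cells (Homo sapiens) for cytotoxicity, read by MTT assay, with a stated time of 24 h; a higher number here means a weaker inhibitor, a lower number a stronger inhibitor.
Compound 2, `NS(=O)(=O)c1ccc(Nc2nc3nc(=S)[nH]c(-c4ccccc4)c3s2)cc1`, gives 333 nM in this assay.
Compound 3, `COc1ccc(-c2[nH]c(=S)nc3nc(Nc4ccc(S(N)(=O)=O)cc4)sc23)cc1`, gives 667 nM in this assay.

Compound 3 sits level with compound 1 at the digits shown, and the two together give the highest numbers of the three. Compound 2 sits somewhat lower, but the step of a 2.0-fold higher number from compound 2 to compound 3 (0.30 log units; within the scatter) lies within the scatter, so no real order among the three can be claimed.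

Compound 4, `NS(=O)(=O)c1ccc(Nc2nc3nc(=S)[nH]c(-c4ccc(Cl)cc4)c3s2)cc1`, differs from compound 3 by chloro in place of methoxy on an aromatic carbon. Going by the values given here, only one measured step touches this position: a 2.0-fold higher number from compound 2 to compound 3 (0.30 log units; within the scatter), where a methoxy entering in place of hydrogen moved the number by an amount within the scatter. Among the compounds with values here, no measured pair compares chloro directly with methoxy on this core; compound 1 carries a chloro group, but on a different core, so its number is only a loose hint. The expectation for compound 4 is therefore a step of a 1.3-fold lower number from compound 3 to compound 4 (0.13 log units; within the scatter), nothing beyond the scatter. Compound 4 is estimated at 500 nM in this assay, with a range from 250 nM to 1000 nM.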

Compound 4, half-maximal inhibitory concentration: 333 nM
Compound 4: the middle estimate sits 1.5-fold (0.18 log units) above what was measured; the measured number falls inside the stated range.
By their numbers in this assay, from the lowest: compounds 2, 4, 1 and 3 (each within the scatter of the next).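

Going by these compounds alone, compound 4 gives the first direct comparison of chloro with methoxy at this carbon of the shared core, and this assay records a 2.0-fold lower number from compound 3 to compound 4 (0.30 log units; within the scatter) for this change, so the two groups cannot be told apart here. It also allows chloro to be compared with hydrogen at the same carbon, where the step is no change at the digits printed from compound 2 to compound 4 (within the scatter) and the three groups tried so far, hydrogen, methoxy and chloro, all stand within the scatter of one another. Nothing measured here offers an explanation for these numbers.

Going by these compounds, whether a different kind of group at this carbon, such as an amine, a carboxylic acid or a longer chain, would shift the number beyond the scatter remains open. On these data alone, it is also open whether the same flat picture would hold on the core of compound 1.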